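Propargyloxy to phenoxy: an expected rise in lipophilicity

The source may report more compounds than this note shows. Statements on the series, on what has been measured and on what is new or still open speak of the compounds shown alone.

compound 1 `CCO/N=C/Nc1cc(Cl)c([S+]([O-])CC)c(Cl)c1`: 2.9
compound 2 `C#CCO/N=C/Nc1cc(Cl)c(CC#C)c(Cl)c1`: 3.3

In a physicochemical assay for lipophilicity, measured as octanol-water partition (a higher number here means a more lipophilic compound, a lower number a more polar compound), compound 2 gives 3.3, the higher of the two numbers; compound 1 gives 2.9, a gap beyond the scatter. Compound 3 `C#CCc1c(Cl)cc(N/C=N/Oc2ccccc2)cc1Cl` awaits measurement. It differs from compound 2 in one place: phenyl in place of propargyl on an oxygen Cut one bond further out, the change reads propargyloxy to phenoxy. Going by the values given here, no measured pair shows this change, so the expectation rests on the structures alone. The expected step in this assay is a number 1.20 log units higher from compound 2 to compound 3 (beyond the scatter), a rise well beyond the scatter. Compound 3 is therefore estimated at 4.5, with a range from 4 to 5.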

Compound 3, partition coefficient: 4.4
The estimate for compound 3 lay 0.10 log units above the measured number, and the stated range covers the measured number.
By their numbers in this assay, from the lowest: compound 1; then compound 2; then compound 3.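

With phenyl in place of propargyl on an oxygen, the series gains its first change in a single place, and in this assay the result is a number 1.10 log units higher from compound 2 to compound 3 (beyond the scatter). The number at this position therefore moves by a large amount when a six-membered aromatic ring replaces a chain holding a triple bond. Nothing available explains the size of this step.

The compounds shown leave open whether the step follows the aromatic ring or the added carbon count. A hexyl chain or a pyridyl ring on the same oxygen would bear on that question.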